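From Isopropoxy to Methylsulfonyl at the Aromatic Carbon

A few compounds are considered here, and "the series" means these few. Any claim that something is new, unique, unknown or untested is made for them only; others in the source may bear on it.

Among the measured compounds shown here, compound 2 `CC(C)Oc1ccccc1OC(C)C1=NCCN1` gives 1740 nM in a functional assay on CHO cells for agonist activity at Alpha-2B adrenergic receptor (Homo sapiens) (on this read-out higher numbers stand for an effect only at larger amounts of compound and lower numbers for an effect already at smaller amounts), the lowest of the two numbers so far; compound 1 `CCc1ccccc1OC(C)C1=NCCN1` gives 10000 nM in this assay. For the measured compounds named here, the only measured step is a 5.7-fold lower number from compound 1 to compound 2 (0.76 log units; beyond the scatter). Compound 3 `CC(Oc1ccccc1S(C)(=O)=O)C1=NCCN1` carries methylsulfonyl in place of isopropoxy on an aromatic carbon. Going by the values given here, no measured compound bears a methylsulfonyl, and the step from ethyl to isopropoxy bears only loosely on this change, leaving the direction open. The author therefore expects a step of a 1.7-fold higher number from compound 2 to compound 3 (0.24 log units; within the scatter), not confidently beyond the scatter. The estimate for compound 3 is 3000 nM, with a range from 800 nM to 12000 nM.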

Compound 3, half-maximal effective concentration: 10000 nM
Estimate against measurement, compound 3: 3.3-fold (0.52 log units) below, within the range that was stated.
By their numbers in this assay, from the lowest: compound 2; then compounds 1 and 3 (each within the scatter of the next).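

In this assay, the move from isopropoxy to methylsulfonyl on this aromatic carbon gives a 5.7-fold higher number from compound 2 to compound 3 (0.76 log units; beyond the scatter), so the lower number seen with isopropoxy is lost. Methylsulfonyl in place of ethyl gives no change at the digits printed from compound 1 to compound 3 (within the scatter), which leaves isopropoxy as the only one of the three groups that stands apart at this position. Nothing available here offers an explanation for this difference. From the compounds shown here alone, whether methoxy or ethoxy would match isopropoxy remains open, as does whether an amine or a carboxylic acid on this carbon would give a lower number still.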